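From Trifluoromethoxy to Phenyl on an Aromatic Ring

The compounds below may be only part of what the source reports. "The series", "measured", "known", "first", "only" and "open" are said of these compounds alone.

Three related compounds have been measured in a functional assay on A549 cells (Homo sapiens) for antiproliferative activity, read by sulforhodamine B assay, with a stated time of 72 h; a lower number here means a stronger inhibitor, a higher number a weaker inhibitor. Compound 1 `COc1ccc(/C=C2\CCC=CC2=O)cc1`, which carries a methoxy group, gives 1460 nM. Compound 3 `COc1ccc(/C=C2\CCC=CC2=O)cc1OC`, which carries a second methoxy group, gives 4680 nM. Compound 2 `O=C1C=CCC/C1=C\c1ccc(OC(F)(F)F)cc1`, which carries trifluoromethoxy instead, gives 440 nM, the lowest number of the three and therefore the strongest inhibitor among them.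

The next compound, compound 4 `O=C1C=CCC/C1=C\c1ccc(-c2ccccc2)cc1`, has not yet been measured. It has phenyl in place of trifluoromethoxy on an aromatic carbon.

Two measured steps offer guidance, though neither involves phenyl. Trifluoromethyl in place of methyl on an oxygen gave a 3.3-fold lower number from compound 1 to compound 2 (0.52 log units; beyond the scatter), while methoxy in place of hydrogen on an aromatic carbon gave a 3.2-fold higher number from compound 1 to compound 3 (0.51 log units; beyond the scatter). Both steps are modest but beyond the scatter, and they run in opposite directions. They suggest a step of similar size, but they do not settle its direction. With compound 2 already lowest at 440 nM, a modest rise seems more likely than a further drop. The expected change is a 2.3-fold higher number from compound 2 to compound 4 (0.36 log units; beyond the scatter). For compound 4, the estimated value is 1000 nM, with an expected range from 250 nM to 4000 nM.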

Compound 4, half-maximal inhibitory concentration: 3670 nM
For compound 4 the middle estimate is 3.7-fold (0.56 log units) below the measured one, within the range that was stated.
By their numbers in this assay, from the lowest: compound 2; then compound 1; then compounds 4 and 3 (each within the scatter of the next).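

Swapping trifluoromethoxy for phenyl brings an 8.3-fold higher number from compound 2 to compound 4 (0.92 log units; beyond the scatter) in this assay and swapping methoxy for phenyl brings a 2.5-fold higher number from compound 1 to compound 4 (0.40 log units; beyond the scatter) at the same place, so phenyl gives a higher number than either of the two oxygen-bearing groups it can be compared with here. Until now, this place on the aromatic ring had been tested only with groups attached through oxygen, and the two results show that a whole carbon ring can stand there while the compound still gives a measurable value, though a weaker one. The change from compound 2 to compound 4 removes a hydrogen-bond acceptor and adds a six-membered aromatic ring at once, so these two differences cannot be told apart, and no measurement shown accounts for the rise.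

As far as these compounds go, it remains open whether the higher number belongs to the phenyl ring itself or would also appear with a simple carbon chain such as ethyl or a longer chain at this place. An amine or a carboxylic acid on the same aromatic carbon, or a phenyl ring carrying a fluorine atom, would help show how far the trend with these groups extends.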